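This account rests on a few compounds, and the source may have more. Where it says the series, first, only, none or still open, it means among the compounds named here.

In a functional assay on HOS cells (Homo sapiens) for antiproliferative activity, read by sulforhodamine B assay (on this read-out higher numbers stand for weaker inhibition of growth and lower numbers for stronger inhibition of growth), compound 1 `CCC[C@@H]1O[C@H](COCc2ccccc2)[C@@H](OCc2ccccc2)[C@H](OCc2ccccc2)[C@H]1O` gives 38600 nM and compound 2 `CC(C)C[C@@H]1O[C@H](COCc2ccccc2)[C@@H](OCc2ccccc2)[C@H](OCc2ccccc2)[C@H]1O` gives 45200 nM in the same read-out. Compound 2 thus stands level with compound 1: the gap is a 1.2-fold higher number from compound 1 to compound 2 (0.07 log units; within the scatter) and nothing more. Compound 3 `C=CC[C@@H]1O[C@H](COCc2ccccc2)[C@@H](OCc2ccccc2)[C@H](OCc2ccccc2)[C@H]1O` differs from compound 2 by vinyl in place of isopropyl on a saturated chain carbon bound to a saturated ring carbon in one place, vinyl in place of isopropyl on a saturated chain carbon bound to a saturated ring carbon, which reads as isobutyl to allyl when cut one bond further out. Going by the values given here, the only measured step on this chain is methyl in place of hydrogen, and no measured compound carries the double bond. Going by a 1.2-fold higher number from compound 1 to compound 2 (0.07 log units; within the scatter) as the sole guide, no step beyond the scatter is expected in this assay in either direction. The estimated change is a 1.1-fold lower number from compound 2 to compound 3 (0.05 log units; within the scatter) and no more. For compound 3 the expected value is 40000 nM within an estimated range of 18000 nM to 80000 nM in this read-out.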

Compound 3, concentration for 50% growth inhibition: 44100 nM
The estimate for compound 3 lay 1.1-fold (0.04 log units) below the measured number, and the stated range covers the measured number.
By their numbers in this assay, from the lowest: compounds 1, 3 and 2 (each within the scatter of the next).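

Vinyl in place of isopropyl on a saturated chain carbon bound to a saturated ring carbon makes no difference beyond the scatter in this assay (a 1.0-fold lower number from compound 2 to compound 3 (0.01 log units; within the scatter)), and vinyl in place of ethyl at the same place does not either (a 1.1-fold higher number from compound 1 to compound 3 (0.06 log units; within the scatter)). Going by these compounds alone, compound 3 is the only compound here with a double bond outside aromatic rings, so this position now tolerates both a branch and a double bond on the shared core without a step beyond the scatter. Nothing at hand bears on why these numbers stay together.

From the compounds shown here alone, all three compounds carry plain hydrocarbon chains at this place, so it remains open whether an amine, a carboxylic acid or a longer chain would move the number beyond the scatter. Going by these compounds, whether this flat picture would hold on any other core also remains open.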